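The source may hold more compounds than are shown below. What is called first, only, known or untested is meant among the compounds shown, and "the series" means these compounds.

Measured so far in an assay on Prostate gland for inhibition of steroid 5-alpha-reductase (Rattus norvegicus); a lower number here means a stronger inhibitor, a higher number a weaker inhibitor:

compound 1 `CCCn1ccc2cc(/C(C)=C/C(=O)Nc3ccccc3OCCCC(=O)O)ccc21`: 190 nM
compound 2 `CCCCn1ccc2cc(/C(C)=C/C(=O)Nc3ccccc3OCCCC(=O)O)ccc21`: 43 nM
compound 3 `CCCCC(C)n1ccc2cc(/C(C)=C/C(=O)Nc3ccccc3OCCCC(=O)O)ccc21`: 6 nM

Compound 4 `CCCCC(CC)n1ccc2cc(/C(C)=C/C(=O)Nc3ccccc3OCCCC(=O)O)ccc21` is not yet measured in this assay.

Compound 4 differs from compound 3 by methyl in place of hydrogen on a saturated chain carbon, two bonds along the chain from an aromatic nitrogen. Compound 2 differs from compound 1 by methyl in place of hydrogen on a saturated chain carbon, three bonds along the chain from an aromatic nitrogen, a step of a 4.4-fold lower number from compound 1 to compound 2 (0.65 log units; beyond the scatter). The two places are not the same word for word: in the earlier pair the carbon is three bonds along the chain from the aromatic nitrogen, in the new pair two bonds, so this is the same kind of change rather than the same change. The cores of compound 1 and compound 3 differ by 1-methylpentyl in place of propyl on an aromatic nitrogen, a step of a 32-fold lower number from compound 1 to compound 3 (1.50 log units; beyond the scatter).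

Compound 3 stands lowest of the three; the step of a 7.2-fold lower number from compound 2 to compound 3 (0.86 log units; beyond the scatter) is beyond the scatter. Going by the values given here, the expected step for compound 4 is a 1.7-fold lower number from compound 3 to compound 4 (0.23 log units; within the scatter), smaller than the earlier one, because compound 3 already sits at 6 nM and only one pair shows the change. Compound 4 is estimated at 3.5 nM, with a range from 1.2 nM to 12 nM.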

Compound 4, half-maximal inhibitory concentration: 7.1 nM
The estimate for compound 4 lay 2.0-fold (0.31 log units) below the measured number; measured number inside the range.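

In this assay, methyl in place of hydrogen on a saturated chain carbon did not give the same step on the two cores: the same change on two cores in this assay, a 4.4-fold lower number (0.65 log units; beyond the scatter) from compound 1 to compound 2 and a 1.2-fold higher number (0.07 log units; within the scatter) from compound 3 to compound 4, 5.2-fold (0.72 log units) apart, beyond the scatter of two such steps

The new step, a 1.2-fold higher number from compound 3 to compound 4 (0.07 log units; within the scatter), is within the scatter, while 1-ethylpentyl still stands apart from the unbranched chains, with a 6.1-fold lower number from compound 2 to compound 4 (0.78 log units; beyond the scatter) and a 27-fold lower number from compound 1 to compound 4 (1.43 log units; beyond the scatter). The carbon is three bonds along the chain from the aromatic nitrogen in one pair and two bonds in the other, so one step size cannot be carried between these cores, and with one pair each the data do not separate the effect of the core from that of the place.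

Still open, going by these compounds, is whether a propyl or longer chain in place of the ethyl of 1-ethylpentyl keeps the number of compound 4 at 7.1 nM. Also open, on these data alone, is how a cyclohexyl group on the aromatic nitrogen would compare.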